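Piperazine for Piperidine on Two Amide Side Chains

The source may report more compounds than this note shows. Statements on the series, on what has been measured and on what is new or still open speak of the compounds shown alone.

Measured compounds:
compound 1 `O=C(CN1CCCCC1)Nc1ccc2ncnc(Nc3cccc(Cl)c3)c2c1`: 12000 nM
compound 2 `CN1CCN(CC(=O)Nc2ccc3ncnc(Nc4cccc(Cl)c4)c3c2)CC1`: > 100000 nM
compound 3 `O=C(CN1CCCCC1)Nc1ccc2ncnc(Nc3ccc(Cl)c(C(F)(F)F)c3)c2c1`: > 100000 nM

In a functional assay on HepG2 cells (Homo sapiens) for antiproliferative activity, read by MTT assay, with a stated time of 48 h (a higher number here means a weaker inhibitor, a lower number a stronger inhibitor), compound 1 gives 12000 nM. For compound 2 the value reported is a limit of the assay, > 100000 nM. The change between the two, (4-methylpiperazin-1-yl in place of piperidin-1-yl on a saturated chain carbon bound to a carbonyl carbon), produced an at least 8.3-fold higher number from compound 1 to compound 2 (0.92 log units; beyond the scatter). For compound 3 the value is likewise a limit of the assay, > 100000 nM. How the core of compound 3 differs from the core of compound 1 is not broken down here. Compound 4 `CN1CCN(CC(=O)Nc2ccc3ncnc(Nc4ccc(Cl)c(C(F)(F)F)c4)c3c2)CC1`, not yet measured, carries the same change as compound 2, (4-methylpiperazin-1-yl in place of piperidin-1-yl on a saturated chain carbon bound to a carbonyl carbon), at the same place. Since (the limit of > 100000 nM in this assay, at which 2 of the 3 values shown sit), compound 4 is expected to stay beyond that limit too, with an estimated step that the limit leaves unreadable from compound 3 to compound 4. Compound 4 is estimated at 300000 nM, between 100000 nM and 1000000 nM.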

Compound 4, half-maximal inhibitory concentration: 25300 nM
The estimate for compound 4 lay 12-fold (1.07 log units) above the measured number; the whole stated range lies above it.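

In this assay, the change from piperidin-1-yl to 4-methylpiperazin-1-yl gives an at least 3.9-fold lower number from compound 3 to compound 4 (0.59 log units; beyond the scatter), whereas on the core of compound 1 it runs the opposite way, so neither its direction nor its size carries from one core to the other: the same change on two cores in this assay, an at least 8.3-fold higher number (0.92 log units; beyond the scatter) from compound 1 to compound 2 and an at least 3.9-fold lower number (0.59 log units; beyond the scatter) from compound 3 to compound 4, at least 32-fold (1.51 log units) apart, beyond the scatter of two such steps. With the 4-methylpiperazin-1-yl side chain held constant, 4-chloro-3-(trifluoromethyl)phenyl in place of 3-chlorophenyl gives an at least 3.9-fold lower number from compound 2 to compound 4 (0.59 log units; beyond the scatter). Going by these compounds, both steps start from a limit of the assay, so their true sizes stay unknown, and this single pair of cores sets no rule for others: the limit of > 100000 nM in this assay, at which 2 of the 4 values shown sit.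

On these data alone, it remains open whether morpholine in place of piperidin-1-yl would follow the same reversal. A longer chain carrying either amine also remains untested among the compounds shown here.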